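The compounds below may be only part of what the source reports. "The series", "measured", "known", "first", "only" and "open" are said of these compounds alone.

Of the compounds shown here, two sharing one core have so far been measured in an assay on isolated protein for inhibition of Rho-associated protein kinase 2 (Homo sapiens); a higher number here means a weaker inhibitor, a lower number a stronger inhibitor. Compound 1 `N[C@H](C(=O)Nc1cc2cc[nH]c(=O)c2cc1Cl)C1CCCCC1` gives 20 nM. Compound 2 `CC(C)C[C@H](N)C(=O)Nc1cc2cc[nH]c(=O)c2cc1Cl` gives 340 nM, the higher of the two numbers. Among the measured compounds shown here, the single step between them, a 17-fold higher number from compound 1 to compound 2 (1.23 log units; beyond the scatter), shows that exchanging the group on the saturated chain carbon bound to an amine nitrogen and a carbonyl carbon moves the read-out well beyond the scatter, so this part of the molecule is sensitive to change. Compound 3 `O=C(Nc1cc2cc[nH]c(=O)c2cc1Cl)[C@@H]1CCCN1` has not yet been measured. It differs from compound 2 in one place: pyrrolidin-2-yl in place of 1-amino-3-methylbutyl on a carbonyl carbon. For the measured compounds named here, the only measured step that bears on this change is a 17-fold higher number from compound 1 to compound 2 (1.23 log units; beyond the scatter); it concerned a different group in the same region, it was large, and it gives no direction for turning the open chain into a five-membered ring. Because of a 17-fold higher number from compound 1 to compound 2 (1.23 log units; beyond the scatter) a sizeable shift either way is possible, so the expected step of a 1.1-fold lower number from compound 2 to compound 3 (0.05 log units; within the scatter) is set near no change with a wide range. Compound 3 is therefore expected to give about 300 nM, within 60 nM to 1500 nM.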

Compound 3, half-maximal inhibitory concentration: 35 nM
Compound 3: middle estimate off by 8.6-fold (0.93 log units), on the high side; the whole stated range lies above it.
By their numbers in this assay, from the lowest: compounds 1 and 3 (each within the scatter of the next); then compound 2.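

In this assay the change from the open 1-amino-3-methylbutyl group to pyrrolidin-2-yl on the carbonyl carbon gives a 9.7-fold lower number from compound 2 to compound 3 (0.99 log units; beyond the scatter) and so shows that this position accepts a five-membered non-aromatic ring that carries the nitrogen within it. The earlier step showed only that cyclohexyl and isobutyl differ, whereas compound 3 at 35 nM now lies within the scatter of compound 1 at 20 nM even though its ring is placed differently, so among these three compounds the two with a ring give the lower numbers and the open-chain compound 2 gives the highest. No measurement shown here explains why the ring change has this effect.

Still open, on these data alone, is whether the ring nitrogen matters, which a cyclopentyl group on the same carbonyl carbon would test, and whether the size of the ring matters, which a six-membered piperidin-2-yl group would test. The compounds shown also leave open what a methyl group on the pyrrolidine nitrogen would do, and how the mirror-image form of pyrrolidin-2-yl would compare.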